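This account rests on a few compounds, and the source may have more. Where it says the series, first, only, none or still open, it means among the compounds named here.

Measured so far in an in vitro functional assay on cells for antagonist activity at metabotropic glutamate receptor 5 (Homo sapiens), read by FLIPR and calcium flux; on this read-out lower numbers stand for stronger inhibition and higher numbers for weaker inhibition:

Compound 1, `Cc1nc2c(cnn2-c2ccccc2)c(=O)n1N1CCCCC1`: 2800 nM
Compound 2, `Cc1ccccc1-n1ncc2c(=O)n(-c3ccc(Cl)cc3)c(C)nc21`: 9500 nM

Of these two values, compound 2 stands at the higher number, and the gap to compound 1 is beyond the usual scatter, so compound 2 is the weaker inhibitor of the pair. Going by the values given here, both compounds share a fused two-ring core; they differ in more than one place, so no single step between them can be read off.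

Compound 3, `Cc1nc2c(cnn2-c2ccc(Cl)cc2)c(=O)n1-c1ccc(Cl)cc1`, keeps the core and the 4-chlorophenyl of compound 2 but carries a different aromatic group on the other ring nitrogen: 4-chlorophenyl in place of 2-methylphenyl on an aromatic nitrogen. Among the compounds with values here, no measured pair shows this change alone, and compound 1 carries an unsubstituted phenyl in that place together with a different group elsewhere, so its value does not isolate the effect.

The step from compound 2 to compound 3 is expected to be modest and toward a lower number, a 2.1-fold lower number from compound 2 to compound 3 (0.32 log units; beyond the scatter). Compound 3 is estimated at 4500 nM in this assay, with a range from 900 nM to 22000 nM.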

Compound 3, half-maximal inhibitory concentration: > 100000 nM
Compound 3 ended at the assay's limit; the forecaster's own chance of this, stated with the estimate: 15%; middle value at least 22-fold (1.34 log units) from the limit.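

Going by these compounds alone, the single change at this position, 4-chlorophenyl in place of 2-methylphenyl on an aromatic nitrogen, gives an at least 10-fold higher number from compound 2 to compound 3 (1.02 log units; beyond the scatter), a large step that the earlier pair, differing in more than one place, could not reveal. The leaving and entering groups are alike in their counts under this comparison, with the same number of heavy atoms, one six-membered aromatic ring of carbon only and no hydrogen-bond donors or acceptors, so these counts alone do not predict the outcome at this position. In this assay compound 3 gives > 100000 nM, which is a limit of the assay and not a number: the limit of > 100000 nM in this assay, at which 1 of the 3 values shown sits.

From the compounds shown here alone, whether the step comes from losing the methyl, gaining the chlorine or both remains open. A 4-methylphenyl or a 2-chlorophenyl at this position would help separate these possibilities.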